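From Bromo to Methoxy on the Aromatic Ring

The source may report more compounds than this note shows. Statements on the series, on what has been measured and on what is new or still open speak of the compounds shown alone.

Compound 1 `O=C(/C=C/c1ccccc1)Nc1ccc2c(c1)COC2=O` and compound 2 `O=C(/C=C/c1ccccc1Br)Nc1ccc2c(c1)COC2=O` share a common core and differ by one group on the aromatic ring. In a functional assay on cells (T-cell, Mus musculus) for inhibition (a higher number here means a weaker inhibitor, a lower number a stronger inhibitor), compound 1 gives 7240 nM. For compound 2 this assay reports only a limit, > 100000 nM, so compound 2 stands at the weak end of what has been measured. Within the data shown here, the single measured step, an at least 13-fold higher number from compound 1 to compound 2 (1.14 log units; beyond the scatter), is the one that bears on the change ahead, and one of the two values sits at the limit (the limit of > 100000 nM in this assay, at which 1 of the 2 values shown sits).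

Compound 3 `COc1ccccc1/C=C/C(=O)Nc1ccc2c(c1)COC2=O` comes next: methoxy in place of bromo on an aromatic carbon. The bromo that leaves is the very group whose entry gave an at least 13-fold higher number from compound 1 to compound 2 (1.14 log units; beyond the scatter), yet methoxy is not hydrogen, so only a partial return is expected, and compound 3 is expected to show an at least 2.5-fold lower number from compound 2 to compound 3 (0.39 log units; beyond the scatter) in this assay. Compound 3 is therefore estimated at 40000 nM, between 10000 nM and 150000 nM.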

Compound 3, half-maximal inhibitory concentration: 39 nM
The estimate for compound 3 lay 1000-fold (3.01 log units) above the measured number; measured number below the stated range.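

The place on the aromatic ring proves far more sensitive to the choice of group than the bromo alone could show: in this assay, swapping bromo for methoxy gives an at least 2500-fold lower number from compound 2 to compound 3 (3.40 log units; beyond the scatter). Methoxy does more than undo the loss seen with bromo, since measured against hydrogen at the same carbon it gives a 190-fold lower number from compound 1 to compound 3 (2.27 log units; beyond the scatter). One place on the ring can thus move the number strongly in either direction, although the value for compound 2 is a limit, so the steps that involve it are bounds: the limit of > 100000 nM in this assay, at which 1 of the 3 values shown sits.

The compounds shown leave open whether the gain is particular to methoxy or would also appear with a hydroxy, an ethoxy or a fluoro group at this carbon. They also leave open whether methoxy would give a similar result on another carbon of this ring.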